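A Side-Chain Exchange on a Shared Core

The compounds below may be only part of what the source reports. "The series", "measured", "known", "first", "only" and "open" are said of these compounds alone.

In a functional assay on MCF7 cells (Homo sapiens) for inhibition, read by MTT assay, with a stated time of 3 days (on this read-out lower numbers stand for stronger inhibition and higher numbers for weaker inhibition), compound 1 `COc1cc(-c2nc3ccccc3s2)ccc1OCC(=O)NNC(=O)CN(C(C)=O)[C@@H](CS)C(=O)O` gives 1750 nM, and compound 2 `COc1cc(-c2nc3ccccc3s2)ccc1OCC(=O)NNC(=O)CNC(=N)NCCC[C@H](N[N+](=O)[O-])C(=O)O` gives 1960 nM. These two numbers lie within the usual scatter of each other, so compound 1 stands level with compound 2 and neither can be ranked above the other.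

Compound 3 `CCOC(=O)[C@@H](NCC(=O)NNC(=O)COc1ccc(-c2nc3ccccc3s2)cc1OC)[C@@H](C)CC` has not yet been measured in this assay. It differs from compound 1 in a single place, ((1-(ethoxycarbonyl)-2-methylbutyl)amino in place of acetyl(1-carboxy-2-sulfanylethyl)amino on a saturated chain carbon bound to a carbonyl carbon). In words, (1-(ethoxycarbonyl)-2-methylbutyl)amino stands in place of acetyl(1-carboxy-2-sulfanylethyl)amino on a saturated chain carbon bound to a carbonyl carbon.

For the measured compounds named here, the data hold no measured step for an exchange of this kind, so the size of its effect cannot be read from any pair of compounds. The expectation rests only on the narrow gap between compound 1 at 1750 nM and compound 2 at 1960 nM. The expected step is a 1.3-fold higher number from compound 1 to compound 3 (0.10 log units; within the scatter), a slight rise in the number that is estimated to stay within the usual scatter. For compound 3 the estimated value is 2200 nM, with an expected range from 800 nM to 6000 nM.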

Compound 3, half-maximal inhibitory concentration: 1950 nM
Estimate against measurement, compound 3: 1.1-fold (0.05 log units) above; the range from low to high includes it.
By their numbers in this assay, from the lowest: compounds 1, 3 and 2 (each within the scatter of the next).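

In this assay, for the compounds shown here, the exchange of acetyl(1-carboxy-2-sulfanylethyl)amino for (1-(ethoxycarbonyl)-2-methylbutyl)amino on a saturated chain carbon bound to a carbonyl carbon gives a 1.1-fold higher number from compound 1 to compound 3 (0.05 log units; within the scatter) and is the first step that can be read at this position. The read-out does not separate these two groups, although they differ in make-up: the group that leaves holds a sulfur atom, 2 hydrogen-bond donors and 1 defined stereocentre, while the group that enters holds no sulfur, 1 hydrogen-bond donor and 2 defined stereocentres. The data offer no evidence that would explain this level result.

Since this single exchange alters the sulfur, the donor count and the stereocentres together, the compounds shown cannot say whether any one of these features matters on its own. They also leave open whether the same level would hold for a much smaller group at this position, such as a plain primary amine, or for a longer chain ending in one.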